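The source may hold more compounds than are shown below. What is called first, only, known or untested is meant among the compounds shown, and "the series" means these compounds.

Measured compounds:
Compound 1 `CCNC(=O)[C@H]1O[C@@H](n2cnc3c(NC)nc(-n4cc(Cc5ccccc5)nn4)nc32)[C@H](O)[C@@H]1O` in an assay on CHO cells for displacement of a labelled ligand from adenosine receptor A3 (Homo sapiens) (a higher number here means a weaker inhibitor, a lower number a stronger inhibitor), gives 2.8 nM
Compound 2 `CCCCc1cn(-c2nc(NC)c3ncn([C@@H]4O[C@H](CO)[C@@H](O)[C@H]4O)c3n2)nn1` in this assay gives 11.7 nM

Of the two numbers, compound 2 stands highest: compound 1 gives a lower number, and the gap between them is beyond the usual scatter. Compound 3 `CNc1nc(-n2cc(Cc3ccccc3)nn2)nc2c1ncn2[C@@H]1O[C@H](CO)[C@@H](O)[C@H]1O` is not yet measured. It differs from compound 2 in one place: phenyl in place of propyl on a saturated chain carbon bound to an aromatic carbon, so that a butyl group becomes a benzyl group on the shared core. Among the measured compounds shown here, no measured pair of compounds shows this change on its own, so the size of the step cannot be read off directly. For the measured compounds named here, what can be said is that the benzyl group is the one carried by compound 1, which gives 2.8 nM, while compound 2 with its butyl group gives 11.7 nM. The step is therefore expected to go toward a lower number, a 2.3-fold lower number from compound 2 to compound 3 (0.37 log units; beyond the scatter), by a moderate amount. Compound 3 is estimated at 5 nM, with a range from 1.5 nM to 16 nM.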

Compound 3, inhibition constant: 9.5 nM
Beside the measured number, compound 3's estimate is 1.9-fold (0.28 log units) below it; low and high end bracket the measured number.
By their numbers in this assay, from the lowest: compound 1; then compounds 3 and 2 (each within the scatter of the next).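

In this assay, phenyl in place of propyl on a saturated chain carbon bound to an aromatic carbon, which turns butyl into benzyl, gives a step that stays within the scatter (a 1.2-fold lower number from compound 2 to compound 3 (0.09 log units; within the scatter)), so on this core the two groups cannot be told apart. The step beyond the scatter lies at the other place, hydroxymethyl in place of ethylcarbamoyl on a saturated ring carbon (a 3.4-fold higher number from compound 1 to compound 3 (0.53 log units; beyond the scatter)), so the lower number of compound 1 goes with its ethylcarbamoyl group and not with the benzyl group, which compound 3 carries too. Nothing at hand gives a reason for either step.

Going by these compounds, it remains open whether butyl and benzyl would also match on the core of compound 1, which carries ethylcarbamoyl. Also open, on these data alone, is how a longer chain at the butyl position, or methylcarbamoyl in place of ethylcarbamoyl, would read.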